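The source may report more compounds than this note shows. Statements on the series, on what has been measured and on what is new or still open speak of the compounds shown alone.

Of the compounds shown here, three have been measured so far in a functional assay on CHO-K1 cells for antagonist activity at C-X-C chemokine receptor type 3 (Homo sapiens), read by FLIPR, with a stated time of 10 min, in the presence of a further agent that is not named here; on this read-out higher numbers stand for weaker inhibition and lower numbers for stronger inhibition. Compound 1 `C[C@@H]1CN(c2sc(C(F)(F)F)nc2-c2nc3cc(OCCO)ccc3[nH]2)CCN1C(=O)Cn1cnc2cccnc21` gives 2.1 nM, compound 2 `C[C@@H]1CN(c2sc(C(F)(F)F)nc2-c2nc3ccccc3[nH]2)CCN1C(=O)Cn1cc(Cl)cn1` gives 1.7 nM, and compound 3 `C[C@@H]1CN(c2sc(C(F)(F)F)nc2-c2nc3ccc(CO)cc3[nH]2)CCN1C(=O)Cn1cnc2cccnc21` gives 4.6 nM. Compound 2 has the lowest number of the three, though its gap to compound 1 lies within the usual scatter, while its gap to compound 3 lies beyond it. The next compound, compound 4 `C[C@@H]1CN(c2sc(C(F)(F)F)nc2-c2nc3ccccc3[nH]2)CCN1C(=O)Cn1cc(C2CCN(C)CC2)cn1`, differs from compound 2 in one place: 1-methylpiperidin-4-yl in place of chloro on an aromatic carbon. Among the compounds with values here, no pair among the measured compounds shows a change at this place, so the effect of this change is not known from them. The expectation is a step of a 2.1-fold higher number from compound 2 to compound 4 (0.31 log units; beyond the scatter), a modest weakening at most. Compound 4 is expected to give about 3.5 nM, within a range of 1 nM to 12 nM.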

Compound 4, half-maximal inhibitory concentration: 15 nM
Beside the measured number, compound 4's estimate is 4.3-fold (0.63 log units) below it, outside the stated range (above it).
By their numbers in this assay, from the lowest: compounds 2 and 1 (each within the scatter of the next); then compound 3; then compound 4.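

Within the data shown here, putting 1-methylpiperidin-4-yl in place of chloro on this aromatic carbon of the five-membered ring gives an 8.8-fold higher number from compound 2 to compound 4 (0.95 log units; beyond the scatter) in this assay, the first measured change at this place. The carbon tolerates a group of seven heavy atoms instead of one, as compound 4 gives 15 nM here, but inhibition weakens beyond the scatter. Nothing measured here gives a reason for this weakening. Going by these compounds, whether the ring or its nitrogen matters more remains open: a cyclohexyl group or a dimethylaminomethyl group on the same carbon would help separate the two.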